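The compounds below may be only part of what the source reports. "The series", "measured", "known", "first", "only" and "open" are said of these compounds alone.

Measured in a functional assay on MCF7 cells (Homo sapiens) for antiproliferative activity, read by MTT assay, with a stated time of 72 h; a lower number here means a stronger inhibitor, a higher number a weaker inhibitor:
Compound 1 `CC(=O)O[C@H]1CC[C@]2(C)[C@H](CC[C@@](C)(O)[C@H]2CC[C@@H]2C(C)=CC[C@H]3[C@H](CC[C@]3(C)OC(C)=O)C2(C)C)OC1(C)C`: 39200 nM
Compound 2 `CC1=CC[C@H]2[C@H](CC[C@]2(C)O)C(C)(C)[C@@H]1CC[C@H]1[C@]2(C)CC[C@H](OC(=O)CCC(=O)O)C(C)(C)O[C@H]2CC[C@@]1(C)O`: > 50000 nM, a limit
Compound 3 `CC1=CC[C@H]2[C@@H]1CC=C(C)[C@@H](CC[C@H]1[C@]3(C)CC[C@H](OC(=O)CCC(=O)O)C(C)(C)O[C@H]3CC[C@@]1(C)O)C2(C)C`: > 50000 nM, a limit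

Compound 2 stands at the limit of > 50000 nM in this assay, at which 2 of the 3 values shown sit. This is a limit and not a number. Of the three measured compounds, only compound 1 has a numerical reading, 39200 nM.

The next structure is compound 4 `CC1=CC[C@H]2[C@H](CC[C@]2(C)O)C(C)(C)[C@@H]1CC[C@H]1[C@]2(C)CC[C@H](OC(=O)NCc3ccccc3)C(C)(C)O[C@H]2CC[C@@]1(C)O`, which has benzylamino in place of 2-carboxyethyl on a carbonyl carbon. For the measured compounds named here, no measured step covers this change, so the expectation is weakly supported. Going by the values given here, the one anchor is compound 1 at 39200 nM, which shows that a number can be obtained in this assay within this small set. A modest move toward stronger inhibition is expected, though compound 4 may still report only as a limit. The estimated step is an at least 2.0-fold lower number from compound 2 to compound 4 (0.30 log units; that floor lies within the scatter). For compound 4 the estimated value is 25000 nM, with an expected range of 9000 nM to 50000 nM.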

Compound 4, half-maximal inhibitory concentration: 24500 nM
Compound 4: the middle estimate sits 1.0-fold (0.01 log units) above what was measured, within the range that was stated.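

In this assay, benzylamino in place of 2-carboxyethyl on a carbonyl carbon gives an at least 2.0-fold lower number from compound 2 to compound 4 (0.30 log units; that floor lies within the scatter). Compound 2 reports only a limit and not a number: the limit of > 50000 nM in this assay, at which 2 of the 4 values shown sit.

With the rest of the structure held, this single change is enough to turn a limit into a numerical reading in this assay, which no measured step had shown for this place.

Open, going by these compounds, is which part of the benzylamino group carries this step: a methylamino or cyclohexylmethylamino group on the same carbonyl carbon would test the need for the six-membered aromatic ring. On these data alone, the full size of the step also stays open, since only its floor can be read from the limit of compound 2.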